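Lengthening the alkyl chain: compound 2 to compound 4

The source may report more compounds than this note shows. Statements on the series, on what has been measured and on what is new or still open speak of the compounds shown alone.

In a functional assay on brain (Rattus norvegicus, strain Wistar) for inhibition (a higher number here means a weaker inhibitor, a lower number a stronger inhibitor), compound 1 (`COc1ccc(-c2c(C)[nH]c(=O)n2C)cc1`) gives 147000 nM, compound 2 (`Cc1[nH]c(=O)n(C)c1-c1ccc(CC(C)C)cc1`) gives 7800 nM and compound 3 (`Cc1[nH]c(=O)n(C)c1-c1ccc(C(C)(C)C)cc1`) gives 8400 nM. Compound 2 therefore stands at the low end of the three numbers, level with compound 3 and far from compound 1.

The next structure is compound 4 (`CCCCCCCCc1ccc(-c2c(C)[nH]c(=O)n2C)cc1`), with heptyl in place of isopropyl on a saturated chain carbon bound to an aromatic carbon.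

Among the compounds with values here, three measured steps bear on this change. Isobutyl in place of methoxy gives a 19-fold lower number from compound 1 to compound 2 (1.28 log units; beyond the scatter), and tert-butyl in place of methoxy gives an 18-fold lower number from compound 1 to compound 3 (1.24 log units; beyond the scatter). Both are large, so replacing methoxy with either alkyl group matters in this assay. Tert-butyl in place of isobutyl gives only a 1.1-fold higher number from compound 2 to compound 3 (0.03 log units; within the scatter), so the two branched groups cannot be told apart here. Within the data shown here, no measured compound carries a chain as long as that of compound 4, and the effect of chain length remains untested. A moderate further fall in the number is the working expectation, well short of the large steps away from methoxy, and a step within the scatter remains possible.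

The expected change is a 2.6-fold lower number from compound 2 to compound 4 (0.41 log units; beyond the scatter). Compound 4 is estimated at 3000 nM, with an expected range of 700 nM to 12000 nM.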

Compound 4, half-maximal inhibitory concentration: 19400 nM
The estimate for compound 4 lay 6.5-fold (0.81 log units) below the measured number; measured number above the stated range.
By their numbers in this assay, from the lowest: compounds 2 and 3 (each within the scatter of the next); then compound 4; then compound 1.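

In this assay, heptyl in place of isopropyl on a saturated chain carbon bound to an aromatic carbon gives a 2.5-fold higher number from compound 2 to compound 4 (0.40 log units; beyond the scatter) as a modest step beyond the scatter, whereas the change between the two branched groups gives only a 1.1-fold higher number from compound 2 to compound 3 (0.03 log units; within the scatter) and stays within it. Alkyl size at this position therefore does register in the number, and a longer chain does not carry the fall seen on leaving methoxy any further: the long chain moves the number up, not down, although the number of compound 4 still stands lower than that of compound 1, with compound 4 giving 19400 nM and compound 1 giving 147000 nM. Nothing on hand accounts for this rise, and the step stands as an observation only.

The compounds shown leave open whether the number climbs steadily with chain length or passes through a minimum at some intermediate chain, which a straight butyl or hexyl group would help to settle. Also open, on these data alone, is whether the chain itself or only its size matters at this position, a question that a cyclohexyl ring, or an amine at the end of the chain, would put to the test.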